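Nitro in place of methyl: working notes on the series

This account rests on a few compounds, and the source may have more. Where it says the series, first, only, none or still open, it means among the compounds named here.

Values so far in a physicochemical assay for lipophilicity, measured as octanol-water partition; a higher number here means a more lipophilic compound, a lower number a more polar compound
- compound 1 `COc1cccc(C(=O)O[C@@H]2C[C@H](C)CC[C@H]2C(C)C)c1` gives 4.57
- compound 2 `Cc1ccc(C(=O)O[C@@H]2C[C@H](C)CC[C@H]2C(C)C)cc1` gives 5.29

Compound 2 stands higher of the two at 5.29 and compound 1 lies below it, beyond the scatter. Compound 3 `CC(C)[C@@H]1CC[C@@H](C)C[C@H]1OC(=O)c1ccc([N+](=O)[O-])cc1` is not yet measured and differs from compound 2 in one place (nitro in place of methyl on an aromatic carbon), with nitro in place of methyl on an aromatic carbon, para to a large group. For the measured compounds named here, no measured step covers this change, so the expectation rests on the structural change alone. In this assay a fall beyond the scatter is expected, of roughly the size of the gap down to compound 1 at 4.57 for reference. The expected change is a number 0.79 log units lower from compound 2 to compound 3 (beyond the scatter) in the downward direction. The estimate for compound 3 is 4.5 with an expected range from 4.1 to 4.9 for the measurement.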

Compound 3, partition coefficient: 4.78
Estimate against measurement, compound 3: 0.28 log units below, and the stated range covers the measured number.
By their numbers in this assay, from the lowest: compounds 1 and 3 (each within the scatter of the next); then compound 2.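

In this assay, for the compounds shown here, nitro in place of methyl on an aromatic carbon, para to a large group, gives a number 0.51 log units lower from compound 2 to compound 3 (beyond the scatter) and so supplies the first measured step that changes one place only. The step is modest but beyond the scatter, which shows that the read-out responds to this exchange at this position, and it runs downward although nitro brings more heavy atoms and, unlike methyl, hydrogen-bond acceptors. Nothing measured on these compounds accounts for the direction or size of the step.

Going by these compounds, whether an amine, a carboxylic acid or a longer chain in the same place would also lower the number remains open. A single step also cannot show whether this exchange would have a similar size on another core.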